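This account rests on a few compounds, and the source may have more. Where it says the series, first, only, none or still open, it means among the compounds named here.

The three measured compounds share one core, seen in compound 1 `COCc1nc2nc(C)cc(Nc3ccc(S(F)(F)(F)(F)F)cc3)n2n1`, compound 2 `Cc1cc(Nc2ccc(S(F)(F)(F)(F)F)cc2)n2nc(C3CC3)nc2n1` and compound 3 `Cc1cc(Nc2ccc(C(F)(F)F)cc2)n2nc(C3CC3)nc2n1`. In a physicochemical assay for lipophilicity, at pH 7.4 (on this read-out higher numbers stand for higher lipophilicity and lower numbers for lower lipophilicity), compound 2 gives 3.5, the highest of the three numbers shown, though its nearest neighbour compound 3 gives 3.3 and sits within the scatter of it, while compound 1 gives 2.8. The step of a number 0.70 log units higher from compound 1 to compound 2 (beyond the scatter) lies beyond the scatter; the step of a number 0.20 log units lower from compound 2 to compound 3 (within the scatter) does not.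

Compound 4 `CCC(F)(F)c1nc2nc(C)cc(Nc3ccc(S(F)(F)(F)(F)F)cc3)n2n1` differs from compound 2 in one place: 1,1-difluoropropyl in place of cyclopropyl on an aromatic carbon. Going by the values given here, of the measured steps, the one from compound 1 to compound 2 bears on this change because it swaps the group on the same aromatic carbon and amounted to a number 0.70 log units higher from compound 1 to compound 2 (beyond the scatter). The step from compound 2 to compound 3 alters another part of the molecule and stays within the scatter, so it says little here. Among the compounds with values here, no measured pair shows cyclopropyl giving way to 1,1-difluoropropyl, so the size of the step can only be gauged loosely. A modest rise in this assay is expected, a number 0.40 log units higher from compound 2 to compound 4 (beyond the scatter). Compound 4 is therefore estimated at 3.9, with a range from 3.5 to 4.3.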

Compound 4, distribution coefficient: 3.9
Compound 4: middle estimate and measured number agree at the digits printed; measured number inside the range.
By their numbers in this assay, from the lowest: compound 1; then compounds 3 and 2 (each within the scatter of the next); then compound 4.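

At this position, on an aromatic carbon between two ring nitrogen atoms, replacing the cyclopropyl ring with the open 1,1-difluoropropyl group moves the number in this assay further up, a number 0.40 log units higher from compound 2 to compound 4 (beyond the scatter). The earlier compounds shown here showed only a modest step at this carbon, whereas the step with the rest of the molecule unchanged now reaches a number 1.10 log units higher from compound 1 to compound 4 (beyond the scatter), which is large. Nothing available explains why the number rises with this change.

The compounds shown do not separate the loss of the ring from the entry of the two fluorine atoms: 1,1-difluoropropyl differs from cyclopropyl in both, and a plain propyl chain at this carbon would pull the two apart. Also open, on these data alone, are whether the same change gives a step of like size on the scaffold of compound 3, which carries trifluoromethyl, and how an amine or a carboxylic acid at this carbon would read in this assay.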